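This account rests on a few compounds, and the source may have more. Where it says the series, first, only, none or still open, it means among the compounds named here.

Of the compounds shown here, three have so far been measured in a functional assay on HL-60 cells (Homo sapiens) for cytotoxicity, read by luminescence and CellTiter-Glo, with a stated time of 3 days; a lower number here means a stronger inhibitor, a higher number a weaker inhibitor. Compound 1 `N#Cc1ccc(NC(=O)c2ccc(F)cc2O)cc1` gives 1380 nM, and compound 2 `O=C(Nc1cc(C(F)(F)F)cc(C(F)(F)F)c1)c1cc(Br)c(-c2ccccc2)cc1O` gives 430 nM. Compound 3 `Cc1cccc(O)c1C(=O)Nc1ccc(C#N)cc1` gives 6860 nM, the highest of the three numbers, and its gap to each of the other two lies beyond the scatter. Compound 4 `N#Cc1ccc(NC(=O)c2c(O)cccc2F)cc1` has not yet been measured in this assay. It differs from compound 3 in a single place: fluoro in place of methyl on an aromatic carbon. For the measured compounds named here, no measured pair shows this same exchange, so its size is uncertain, but a modest move toward a lower number is expected, since compound 1 with a fluoro on the same acid gives 1380 nM. The expected step is a 2.3-fold lower number from compound 3 to compound 4 (0.36 log units; beyond the scatter). Compound 4 is thus estimated at 3000 nM, within a range from 900 nM to 10000 nM.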

Compound 4, half-maximal inhibitory concentration: > 10000 nM
Compound 4 ended at the assay's limit; the forecaster's own chance of this, stated with the estimate: 5%; middle value at least 3.3-fold (0.52 log units) away from the limit.
By their numbers in this assay, from the lowest: compound 2; then compound 1; then compound 3. At a limit, above all of these: compound 4.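

For the compounds shown here, this is the first step at this position, the aromatic carbon ortho to a large group and meta to a hydroxy group. In this assay, compound 4 stands at a limit of the assay, > 10000 nM. Fluoro in place of methyl here gives an at least 1.4-fold higher number from compound 3 to compound 4 (0.16 log units; that floor lies within the scatter), so the exchange brings no move toward a lower number, and only a floor on its size can be read.

The compounds shown leave open how far the true value of compound 4 lies past that limit. They also leave open what a chloro, methoxy or amine at this carbon would give.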